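A few compounds are considered here, and "the series" means these few. Any claim that something is new, unique, unknown or untested is made for them only; others in the source may bear on it.

Measured values (a functional assay (aorta) with Rattus norvegicus as the target; on this read-out lower numbers stand for stronger inhibition and higher numbers for weaker inhibition):
Compound 1 `CC(C)c1cn2ccccc2c1S(=O)(=O)c1ccc(OCCCN(C)C)cc1` gives 390 nM
Compound 2 `CCCCN(CCCC)CCCOc1ccc(S(=O)(=O)c2c(C(C)C)cn3ccccc23)cc1` gives 21.6 nM

Of these two numbers, compound 2 has the lower (21.6 nM). Compound 3 `CCCCN(CCCC)CCCOc1ccc(S(=O)(=O)c2c(CCC)cn3ccccc23)cc1` differs from it in one group (propyl in place of isopropyl on an aromatic carbon): propyl in place of isopropyl on an aromatic carbon. Going by the values given here, the only measured step (an 18-fold lower number from compound 1 to compound 2 (1.26 log units; beyond the scatter)) is large, but it puts dibutylamino in place of dimethylamino, at another place, so it gives no direct guide here. Among the compounds with values here, no measured step touches this carbon. The two compounds have the same atoms, joined differently, so no shift beyond the scatter is expected in this assay, and the estimated step is small (a 1.6-fold higher number from compound 2 to compound 3 (0.21 log units; within the scatter)). The estimate for compound 3 is 35 nM with an expected range from 10 nM to 120 nM in this assay.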

Compound 3, half-maximal inhibitory concentration: 54.3 nM
For compound 3 the middle estimate is 1.6-fold (0.19 log units) below the measured one; measured number inside the range.
By their numbers in this assay, from the lowest: compound 2; then compound 3; then compound 1.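

In this assay, propyl in place of isopropyl on this aromatic carbon gives a 2.5-fold higher number from compound 2 to compound 3 (0.40 log units; beyond the scatter) and so shows that this position responds even when the atoms stay the same and only their joining differs. Going by these compounds alone, the earlier step changed only the amine, so this is the first reading at this carbon. Nothing available explains the shift. Still open, as far as these compounds go, is how a methyl, an ethyl or a cyclopropyl group would fare here, and whether the same change would give a similar step with dimethylamino in place of dibutylamino.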